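Working notes on the aryl group of the shared core

The source may hold more compounds than are shown below. What is called first, only, known or untested is meant among the compounds shown, and "the series" means these compounds.

Three compounds differing only in the aryl group on the shared core have been measured. Compound 1 `c1ccc(-c2cn3ccnc3c(-c3ccc4ncn(C5CCCCC5)c4c3)n2)cc1` gives 59.5% in a functional assay on HCT-116 cells (Homo sapiens) for inhibition, read by sulforhodamine B assay, with a stated time of 48 h, tested at 10 uM; a higher number here means more inhibition at the concentration tested (going by the name of the read-out), a lower number less inhibition. Compound 2 `c1ccc2c(-c3cn4ccnc4c(-c4ccc5ncn(C6CCCCC6)c5c4)n3)cccc2c1` gives 17.9% in this assay, and compound 3 `c1cn2cc(-c3ccsc3)nc(-c3ccc4ncn(C5CCCCC5)c4c3)c2n1` gives 13.4%. Compound 2 stands second highest of the three numbers: its nearest neighbour is compound 3, a gap within the scatter, and its furthest is compound 1, a gap beyond the scatter. The measured steps are a number 41.6 percentage points lower from compound 1 to compound 2 (beyond the scatter), a number 46.1 percentage points lower from compound 1 to compound 3 (beyond the scatter) and a number 4.5 percentage points lower from compound 2 to compound 3 (within the scatter).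

Compound 4 `CC(=O)c1ccc(-c2cn3ccnc3c(-c3ccc4ncn(C5CCCCC5)c4c3)n2)cc1` has not been measured. Its change from compound 2 is 4-acetylphenyl in place of naphthalen-1-yl on an aromatic carbon. The step that bears on it is the large drop from compound 1 to compound 2, which this change largely reverses, as a single six-membered aromatic ring of carbon only comes back in place of naphthalen-1-yl. Among the measured compounds shown here, the acetyl group has no measured counterpart, so the width of the estimate is kept wide. A rise beyond the scatter in this assay is expected, short of the value of compound 1. Compound 4 is expected to give 45%, within 18% to 72%. This estimate means an expected step of a number 27.1 percentage points higher from compound 2 to compound 4 (beyond the scatter).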

Compound 4, a percentage reported as inhibition, at one concentration (the size of the read-out at that concentration, not a potency): 15.9%
Estimate against measurement, compound 4: 29.1 percentage points above, and the stated range ends above it.
By their numbers in this assay, from the lowest: compounds 3, 4 and 2 (each within the scatter of the next); then compound 1.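

In this assay the move to 4-acetylphenyl gives a number 43.6 percentage points lower from compound 1 to compound 4 (beyond the scatter) from one added group, so a single six-membered aromatic ring of carbon only does not by itself keep the number of compound 1. The other two comparisons give a number 2 percentage points lower from compound 2 to compound 4 (within the scatter) and a number 2.5 percentage points higher from compound 3 to compound 4 (within the scatter) and so, of the four aryl groups, only the unsubstituted phenyl of compound 1 stands apart, while naphthalen-1-yl, thiophen-3-yl and 4-acetylphenyl sit together. Nothing on hand explains why the unsubstituted phenyl stands apart.

Still open, from the compounds shown here alone, is whether the fall belongs to the acetyl group in particular or to any group added at that carbon of the phenyl ring. A methyl group, a fluorine atom, an amine or a carboxylic acid there could settle whether any substituted phenyl keeps the number of compound 1.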